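Acetylation of the Free Hydroxy in Compound 3

The source may hold more compounds than are shown below. What is called first, only, known or untested is meant among the compounds shown, and "the series" means these compounds.

Working notes on a set of ester derivatives of a shared core, all tested in a functional assay on HeLa cells (Homo sapiens) for cytotoxicity, read by MTT assay, with a stated time of 72 h; on this read-out higher numbers stand for weaker inhibition and lower numbers for stronger inhibition. Compound 1 `COc1ccc(C(=O)O[C@H]2CC(C)=C[C@H](O)[C@@]3(C)[C@@H](OC(C)=O)C[C@@](O)(C(C)C)[C@H]23)cc1` gives 52900 nM. Compound 2 `COc1ccc(C(=O)O[C@H]2CC(C)=C[C@@H](OC(C)=O)[C@@]3(C)[C@@H](OC(C)=O)C[C@@](O)(C(C)C)[C@H]23)cc1` returns only a limit, > 100000 nM, which is not a number. Compound 3 `COc1ccc(C(=O)O[C@H]2CC(C)=C[C@H](OC(C)=O)[C@]3(C)[C@@H]2[C@](O)(C(C)C)C[C@@H]3O)cc1` gives 52600 nM. The number for compound 3 and the number for compound 1 lie within the scatter of each other, so the two stand together and neither is called the weaker or stronger of the pair. Going by the values given here, of the three values shown, one sits at the limit of > 100000 nM in this assay, at which 1 of the 3 values shown sits, so readable numbers exist for only two compounds.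

Compound 4 `COc1ccc(C(=O)O[C@H]2CC(C)=C[C@H](OC(C)=O)[C@@]3(C)[C@@H](OC(C)=O)C[C@@](O)(C(C)C)[C@H]23)cc1` differs from compound 3 by acetyl in place of hydrogen on an oxygen on a saturated carbon, which at one bond further out reads as hydroxy to acetoxy. Among the compounds with values here, no two measured compounds differ in one place only, so no measured step fixes the size of this change. The expectation is a small step toward weaker inhibition, or none beyond the scatter. The value of compound 4 is estimated at 80000 nM. The range expected for compound 4 runs from 35000 nM to 200000 nM. This estimate means an expected step of a 1.5-fold higher number from compound 3 to compound 4 (0.18 log units; within the scatter), with a fair chance that only a limit is reported.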

Compound 4, half-maximal inhibitory concentration: 14500 nM
Compound 4: middle estimate off by 5.5-fold (0.74 log units), on the high side, outside the stated range (below it).
By their numbers in this assay, from the lowest: compound 4; then compounds 3 and 1 (each within the scatter of the next). At a limit, above all of these: compound 2.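

Acetyl in place of hydrogen on an oxygen on a saturated carbon is the first change in the series with a readable effect in this assay, and it gives a lower number at two different oxygens of the shared core, with a 3.6-fold lower number from compound 3 to compound 4 (0.56 log units; beyond the scatter) and a 3.6-fold lower number from compound 1 to compound 4 (0.56 log units; beyond the scatter). Both steps lie beyond the scatter, so the acetoxy group at each of these places goes with stronger inhibition than the hydroxy group it replaces. Configuration at one saturated ring carbon also counts, as compound 2 carries the same atoms and bonds as compound 4 and goes against any reading of acetylation alone, with an at least 6.8-fold lower number from compound 2 to compound 4 (0.83 log units; beyond the scatter): the fact that compounds 2 and 4 differ only in the configuration as drawn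

From the compounds shown here alone, compound 2 gives only a limit, so the full size of that configurational step stays open: the limit of > 100000 nM in this assay, at which 1 of the 4 values shown sits. Also open is whether the lower number belongs to the acetyl group in particular or to esters at these oxygens in general, which a longer chain such as butanoyl, a benzoyl group or an amine in place of the acetoxy group would help to separate.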